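Adding a Methoxy to Compound 2

A few compounds are considered here, and "the series" means these few. Any claim that something is new, unique, unknown or untested is made for them only; others in the source may bear on it.

In an ADME assay on THP-1 cells (Homo sapiens) for cytotoxicity, read by flow cytometry and propidium iodide staining, with a stated time of 72 h (on this read-out higher numbers stand for weaker inhibition and lower numbers for stronger inhibition), compound 2 `Nc1ccc2oc(-c3cccc(F)c3)cc(=O)c2c1` gives > 125000 nM, which is a limit of the assay and not a number. Compound 1 `CC(=O)Nc1ccc2oc(-c3cccc(F)c3)cc(=O)c2c1`, which carries an acetyl on its nitrogen, gives > 125000 nM, and this too is a limit. Compound 3 `Nc1ccc2oc(-c3cccc(C(F)(F)F)c3)cc(=O)c2c1` gives an actual number, 34000 nM. Compound 2 therefore has no exact place on the scale, and the picture so far rests on (the limit of > 125000 nM in this assay, at which 2 of the 3 values shown sit).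

Compound 4 `COc1c(-c2cccc(F)c2)oc2ccc(N)cc2c1=O` differs from compound 2 by a single change: methoxy in place of hydrogen on an aromatic carbon. Two measured steps share the core, but neither touches this place. Removing the acetyl gave a step that the two limits leave unreadable from compound 1 to compound 2, so it offers no size to borrow. Exchanging fluoro for trifluoromethyl gave an at least 3.6-fold lower number from compound 2 to compound 3 (0.56 log units; beyond the scatter). Among the compounds with values here, this is the only readable step, and it shows that one small change can bring a number under the limit, but it concerns a different group and a different place, so it carries over only loosely. The expected result is an at least 1.1-fold lower number from compound 2 to compound 4 (0.05 log units; that floor lies within the scatter), a small step if any, and more likely towards a lower number. The assay may well report only a limit again. For compound 4 the estimated value is 110000 nM, with an expected range from 40000 nM to 250000 nM.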

Compound 4, half-maximal inhibitory concentration: 34000 nM
Compound 4: middle estimate off by 3.2-fold (0.51 log units), on the high side; the whole stated range lies above it.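

In this assay, within the data shown here, putting a methoxy on this aromatic carbon, ortho to the 3-fluorophenyl group, gives an at least 3.6-fold lower number from compound 2 to compound 4 (0.56 log units; beyond the scatter), so a place on the shared core that no earlier step touched also responds to a single change, with inhibition growing stronger. Among these compounds, until now the only readable step lay on the other ring, an at least 3.6-fold lower number from compound 2 to compound 3 (0.56 log units; beyond the scatter), and the two readable steps from compound 2 now both point towards a lower number, although they involve different groups at different places. The new step is a floor and not a full size, and the reason lies in where it starts: the limit of > 125000 nM in this assay, at which 2 of the 4 values shown sit.

Methoxy is the only group shown at this place, so it stays open whether a hydroxy, an ethoxy or a longer chain would move the number further, or whether a plain methyl would do the same. Going by these compounds, it also stays open how the methoxy behaves when the same core carries the trifluoromethyl of compound 3 or the acetyl on the nitrogen of compound 1.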